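The source may hold more compounds than are shown below. What is called first, only, known or untested is meant among the compounds shown, and "the series" means these compounds.

Compound 1 `Cc1ccncc1-c1cc(F)cc(-n2nnc(-c3ncc[nH]3)n2)c1` gives the lowest number of the three measured compounds in an assay for binding affinity to metabotropic glutamate receptor 5 (Rattus norvegicus) (on this read-out lower numbers stand for stronger inhibition and higher numbers for weaker inhibition), namely 3.5 nM. Compound 3 `N#Cc1cc(F)cc(-n2nnc(-c3ncc[nH]3)n2)c1` gives 9.3 nM, and compound 2 `N#Cc1cccc(-n2nnc(-c3ncc[nH]3)n2)c1` gives 34 nM. Two single changes connect these compounds: the step of a 2.7-fold higher number from compound 1 to compound 3 (0.42 log units; beyond the scatter), in which a cyano group takes the place of the 4-methylpyridin-3-yl group, and the step of a 3.7-fold lower number from compound 2 to compound 3 (0.56 log units; beyond the scatter), in which a fluoro takes the place of a hydrogen on an aromatic carbon. Compound 4 `Cc1ccncc1-c1cc(F)cc(-n2nnc(-c3ccccn3)n2)c1` differs from compound 1 at a different place: pyridin-2-yl in place of 1H-imidazol-2-yl on an aromatic carbon. The group that enters sits on an aromatic carbon of the five-membered ring of the shared core, between two ring nitrogen atoms. Within the data shown here, neither of the measured steps touches this part of the core, so no measured step bears on this change, and its effect cannot be read from the data at hand. The expectation for compound 4 is therefore uncertain and carries a wide range. For compound 4 a modest weakening is expected, the estimated step of a 2.9-fold higher number from compound 1 to compound 4 (0.46 log units; beyond the scatter). Compound 4 is thus expected to give 10 nM in this assay, within a range from 2 nM to 60 nM.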

Compound 4, inhibition constant: 1.8 nM
Estimate against measurement, compound 4: 5.6-fold (0.74 log units) above; the measured number lies below the stated range.
By their numbers in this assay, from the lowest: compounds 4 and 1 (each within the scatter of the next); then compound 3; then compound 2.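

In this assay, the step of a 1.9-fold lower number from compound 1 to compound 4 (0.29 log units; within the scatter) shows that this position, on an aromatic carbon of the five-membered ring of the shared core, between two ring nitrogen atoms, can carry either pyridin-2-yl or 1H-imidazol-2-yl with no difference that stands out from the scatter. The change swaps a five-membered aromatic ring for a six-membered one, and the group that leaves has a hydrogen-bond donor while the group that enters has none, so in this pair neither the ring size nor that donor separates the two numbers. Nothing available here explains why the two groups read alike.

The compounds shown hold only these two aromatic rings at this position, so it stays open whether a phenyl ring, with no ring nitrogen, or a non-aromatic group such as an amine, a carboxylic acid or a short alkyl chain would be tolerated as well. Going by these compounds, it also stays open whether pyridin-2-yl would read the same on the nitrile-bearing compound 2 and compound 3 as it does on compound 1.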